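Trifluoromethyl on the pyridine of an imidazoline agonist

A few compounds are considered here, and "the series" means these few. Any claim that something is new, unique, unknown or untested is made for them only; others in the source may bear on it.

Measured so far:
compound 1 `c1ccc(-c2ccccc2NCC2=NCCN2)nc1`, 30.2 nM
compound 2 `c1ccc(-c2cnccn2)c(NCC2=NCCN2)c1`, 339 nM

In a functional assay for activation of Alpha-1B adrenergic receptor (Homo sapiens), read by calcium flux (a higher number here means that more compound is needed for the effect, a lower number that less compound is needed), compound 1 gives 30.2 nM, the lowest of the two numbers; compound 2 gives 339 nM, with an 11-fold higher number from compound 1 to compound 2 (1.05 log units; beyond the scatter). Compound 3 `FC(F)(F)c1cccnc1-c1ccccc1NCC1=NCCN1` differs from compound 1 by trifluoromethyl in place of hydrogen on an aromatic carbon. Among the compounds with values here, no measured step involves a trifluoromethyl group, and the one step known, from compound 1 to compound 2, concerns a different ring. He therefore expects compound 3 to change only modestly, estimating 60 nM (range 15 nM to 300 nM), an expected step of a 2.0-fold higher number from compound 1 to compound 3 (0.30 log units; within the scatter).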

Compound 3, half-maximal effective concentration: < 100000 nM
Compound 3: only a limit was reported; the forecaster's own chance of this, stated with the estimate: 3%; the middle value does not contradict the limit.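

In this assay compound 3 gives < 100000 nM as a limit and not a number, so the step from compound 1 to compound 3 cannot be read. The compounds shown leave open whether in this assay trifluoromethyl in place of hydrogen on an aromatic carbon raises or lowers the number.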